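Aryl exchange on the ring nitrogen: notes toward compound 3

This account rests on a few compounds, and the source may have more. Where it says the series, first, only, none or still open, it means among the compounds named here.

compound 1, `O=c1ccc2cc(OCc3cn(-c4ccccc4Cl)nn3)ccc2o1` — 17100 nM
compound 2, `O=c1ccc2cc(OCc3cn(-c4ccc(Cl)c(Cl)c4)nn3)ccc2o1` — "not determined" (no result reported)
compound 3, `O=c1ccc2cc(OCc3cn(-c4ccccc4[N+](=O)[O-])nn3)ccc2o1` — not yet measured

Among the measured compounds shown here, in a functional assay on A549 cells (Homo sapiens) for cytotoxicity, read by MTT assay, with a stated time of 48 h (a lower number here means a stronger inhibitor, a higher number a weaker inhibitor), compound 1 gives 17100 nM, a weak inhibition and the only number so far. In this assay compound 2 stands at "not determined" (no result reported); no result was reported, so its place relative to compound 1 cannot be read off, and nothing can be said about the distance between the two.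

Compound 3 differs from compound 2 by 2-nitrophenyl in place of 3,4-dichlorophenyl on an aromatic nitrogen, in words 2-nitrophenyl in place of 3,4-dichlorophenyl on an aromatic nitrogen. For the measured compounds named here, no measured pair shows how large a step this kind of change produces, so no size or direction is expected beyond what the scatter allows; the only anchor is the weak result of compound 1 in this assay. On that anchor alone, compound 3 is expected to give about 17000 nM in this assay, with a range from 5000 nM to 60000 nM.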

Compound 3, half-maximal inhibitory concentration: 10200 nM
Beside the measured number, compound 3's estimate is 1.7-fold (0.22 log units) above it, within the range that was stated.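

In this assay, the step of a 1.7-fold lower number from compound 1 to compound 3 (0.22 log units; within the scatter) gives the series its first reading of a change on the aryl group carried by the aromatic nitrogen. On this one pair, nitro in place of chloro on an aromatic carbon cannot be told apart from no effect, so 2-nitrophenyl and the chloro-bearing aryl group of compound 1 stand level. Steps involving compound 2 cannot be read, and nothing measured bears on what lies behind this result.

Open, going by these compounds, is whether an amine or a carboxylic acid on the same aryl ring would give a step beyond the scatter. Also open, on these data alone, is whether a benzyl group or a longer alkyl chain on the aromatic nitrogen would move the number away from this level.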